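Swapping Ethyl for Hydrogen on Compound 3

This account rests on a few compounds, and the source may have more. Where it says the series, first, only, none or still open, it means among the compounds named here.

In a functional assay on the whole organism (strain Hartley) for inhibition, with Cavia porcellus as the target, with stated times of 15 min and 2 min (a higher number here means that more compound is needed for the effect, a lower number that less compound is needed), compound 1 (`CCCCC1([C@H](O)/C=C/C2CCC(=O)[C@@H]2CCCCCC(=O)O)CCC1`) gives 0.032 mg/kg and compound 2 (`CCCCC1([C@H](O)/C=C/C2[C@H](O)CC(=O)[C@@H]2C/C=C\CCCC(=O)O)CCC1`) gives 0.00154 mg/kg as its reading. Compound 3 (`CCCCC1([C@H](O)/C=C/C2CCC(=O)[C@@H]2C/C=C\CCCC(=O)OCC)CCC1`) stands highest of the three at 0.221 mg/kg and lies beyond the scatter from both others, so more of it is needed for the effect.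

Compound 4 (`CCCCC1([C@H](O)/C=C/C2CCC(=O)[C@@H]2C/C=C\CCCC(=O)O)CCC1`) has not been measured. It differs from compound 3 by one change (hydrogen in place of ethyl on an oxygen next to a carbonyl group), with hydrogen in place of ethyl on an oxygen next to a carbonyl group, so that ethoxycarbonyl becomes carboxy.

Among the measured compounds shown here, no measured pair shows this change alone. The expectation therefore rests on compound 1 at 0.032 mg/kg and compound 2 at 0.00154 mg/kg as neighbours. Both carry the carboxy group and both have lower numbers than compound 3, although they also differ from compound 4 elsewhere. An expected step (a 6.3-fold lower number from compound 3 to compound 4 (0.80 log units; beyond the scatter)) toward a lower number in this assay would lie beyond the scatter. The estimate for compound 4 is 0.035 mg/kg (expected range 0.008 mg/kg to 0.15 mg/kg).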

Compound 4, dose for half-maximal effect: 0.0022 mg/kg
Estimate against measurement, compound 4: 16-fold (1.20 log units) above; measured number outside the range, below it.
By their numbers in this assay, from the lowest: compounds 2 and 4 (each within the scatter of the next); then compound 1; then compound 3.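

In this assay, among the compounds shown here, hydrogen in place of ethyl on an oxygen next to a carbonyl group, which turns ethoxycarbonyl into carboxy, gives a 100-fold lower number from compound 3 to compound 4 (2.00 log units; beyond the scatter) as a large step, and this is the first reading of that change alone. With the carboxy group in place, hydrogen in place of hydroxy on a saturated ring carbon gives only a 1.4-fold higher number from compound 2 to compound 4 (0.15 log units; within the scatter) within the scatter, whereas 5-carboxypent-1-en-1-yl in place of 4-carboxybutyl gives a 15-fold lower number from compound 1 to compound 4 (1.16 log units; beyond the scatter) as a second large step. Nothing available gives a reason for the size of these steps.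

Going by these compounds, whether a methyl ester, an amide or a tetrazole on the same chain would read nearer compound 3 or compound 4 remains open. So does whether a longer chain ending in a carboxy group would keep the reading of compound 4.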